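The compounds below may be only part of what the source reports. "The series", "measured", "known", "first", "only" and "open" are said of these compounds alone.

Compound 1 `CO[C@@H]1C/C=C(\C)C(=O)N(C)[C@@H](C(C)C)C(=O)N[C@H](Cc2ccccc2)C(=O)N[C@@H](C(C)C)C(=O)O[C@H](c2ccccc2)[C@H](C)/C=C/C=C/1C`: > 100 nM in a functional assay on HCT-116 cells (Homo sapiens) for antiproliferative activity, read by MTT assay, with a stated time of 72 h; a lower number here means a stronger inhibitor, a higher number a weaker inhibitor; this is a limit of the assay, not a number.
Compound 2 `CC[C@H](C)[C@H]1C(=O)N[C@H](Cc2ccc(O)c(OC)c2)C(=O)N[C@@H](C(C)(C)O)C(=O)O[C@H](c2ccccc2)[C@H](C)/C=C/C=C(\C)[C@H](OC)C[C@@H]2O[C@@]2(C)C(=O)N1C`: 25.2 nM in this assay.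
Compound 3 `CO[C@@H]1C[C@@H]2O[C@@]2(C)C(=O)N[C@@H](C(C)C)C(=O)N[C@H](Cc2cc(Cl)c(O)c(Cl)c2)C(=O)N[C@@H](C(C)(C)O)C(=O)O[C@H](c2ccccc2)[C@H](C)/C=C/C=C/1C`: "not active" (no number reported) in this assay, with no number reported.

Among the compounds with values here, compound 2 thus stands as the only compound of the three with a numerical result in this assay. Compound 1 sits at a limit (the limit of > 100 nM in this assay, at which 1 of the 3 values shown sits), and compound 3 carries only a verbal report without a number.

Compound 4 `CC[C@H](C)[C@H]1C(=O)N[C@H](Cc2cc(Cl)c(O)c(Cl)c2)C(=O)N[C@@H](C(C)(C)O)C(=O)O[C@H](c2ccccc2)[C@H](C)/C=C/C=C(\C)[C@H](OC)C[C@@H]2O[C@@]2(C)C(=O)N1C` differs from compound 2 in one place: 3,5-dichloro-4-hydroxyphenyl in place of 4-hydroxy-3-methoxyphenyl on a saturated chain carbon bound to a saturated ring carbon. Within the data shown here, no pair of measured compounds that differ in a single place is available, so the size of this step cannot be read from the data. The change is expected to cost some potency, a moderate step of a 4.0-fold higher number from compound 2 to compound 4 (0.60 log units; beyond the scatter). Compound 4 is estimated at 100 nM, within a range from 25 nM to 500 nM.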

Compound 4, half-maximal inhibitory concentration: 17 nM
Estimate against measurement, compound 4: 5.9-fold (0.77 log units) above; measured number below the stated range.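

In this assay the position now has its first readable step, a 1.5-fold lower number from compound 2 to compound 4 (0.17 log units; within the scatter) with 3,5-dichloro-4-hydroxyphenyl in place of 4-hydroxy-3-methoxyphenyl. The potency of compound 2 is therefore kept with this group on a saturated chain carbon bound to a saturated ring carbon, and the two compounds cannot be ranked. Nothing shown accounts for this result. Steps to compound 1 and compound 3 cannot be read, as each differs from these compounds in more than one place. As far as these compounds go, whether an aminophenyl or a carboxyphenyl group would also keep this potency stays open.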